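Halogenated anilide series: cytotoxicity notes toward compound 4

This account rests on a few compounds, and the source may have more. Where it says the series, first, only, none or still open, it means among the compounds named here.

Three anilides sharing one core have been run in a toxicity assay on HepG2 cells (Homo sapiens) for inhibition, read by CellTiter-Glo, with a stated time of 48 h; on this read-out higher numbers stand for weaker inhibition and lower numbers for stronger inhibition. Compound 1 `COc1ccc2nc(C)cc(OCC(=O)Nc3cc(C)ccc3C)c2c1` reaches only the assay limit, with > 100000 nM in this assay. Compound 2 `COc1ccc(NC(=O)COc2cc(C)nc3ccc(OC)cc23)cc1` likewise stops at the limit, giving > 100000 nM in this assay. Among the compounds with values here, compound 3 `COc1ccc2nc(C)cc(OCC(=O)Nc3ccc(Br)c(C)c3)c2c1` is the single member with a read number, 15900 nM in this assay, and so stands as the only firm point among the three. The other two values sit at a limit of the assay (the limit of > 100000 nM in this assay, at which 2 of the 3 values shown sit). The moves an at least 6.2-fold lower number from compound 1 to compound 3 (0.79 log units; beyond the scatter) and an at least 6.2-fold lower number from compound 2 to compound 3 (0.79 log units; beyond the scatter) both bring a readable number out of a limit, while the move a step that the two limits leave unreadable from compound 1 to compound 2 cannot be sized at all. No pattern beyond these three can be claimed.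

Compound 4 `COc1ccc2nc(C)cc(OCC(=O)Nc3ccc(Cl)c(OC)c3)c2c1` has not been measured. It differs from compound 3 by 4-chloro-3-methoxyphenyl in place of 4-bromo-3-methylphenyl on an amide-type nitrogen. Only the two steps ending at compound 3 bear on this change, and neither leaves a limit readable in size, so the exchange of one halogen and one small substituent for another on the amide-bearing ring is expected to shift the number by a 1.9-fold higher number from compound 3 to compound 4 (0.28 log units; within the scatter) or less. Compound 4 is therefore estimated at 30000 nM in this assay, within a range of 9000 nM to 100000 nM, with a fair chance of returning only a limit.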

Compound 4, half-maximal inhibitory concentration: > 100000 nM
Compound 4: only a limit was reported; the forecaster's own chance of this, stated with the estimate: 35%; middle value at least 3.3-fold (0.52 log units) away from the limit.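

Within the data shown here, on the amide-type nitrogen, 4-chloro-3-methoxyphenyl in place of 4-bromo-3-methylphenyl gives an at least 6.2-fold higher number from compound 3 to compound 4 (0.79 log units; beyond the scatter) in this assay, so the single readable number does not survive this exchange on the amide-bearing ring. In this assay compound 4 gives > 100000 nM, which is a limit of the assay and not a number. Until now the limit compounds carried no halogen, but compound 4 carries chlorine in its group and still sits at the limit, so a halogen on this ring is not enough on its own to give a read number, and compound 3 remains the only firm point: the limit of > 100000 nM in this assay, at which 3 of the 4 values shown sit.

The steps to compound 4 from compound 1 and from compound 2 cannot be read, and the exchange swaps bromine for chlorine and methyl for methoxy at once, so the compounds shown do not tell which of the two changes carries the step. Still open, from the compounds shown here alone, is how 4-bromo-3-methoxyphenyl or 4-chloro-3-methylphenyl on the same nitrogen would read in this assay, which would separate the two changes, and how a ring bearing an amine or a carboxylic acid would read.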